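This account rests on a few compounds, and the source may have more. Where it says the series, first, only, none or still open, it means among the compounds named here.

Working notes on the series. Compound 2 `Cn1nc(CCCO[Si](c2ccccc2)(c2ccccc2)C(C)(C)C)ccc1=O` sits at the edge of what this series has shown: in a functional assay on aorta (Rattus norvegicus) (on this read-out higher numbers stand for weaker inhibition and lower numbers for stronger inhibition), compound 2 gives > 100000 nM, which is a limit of the assay and not a number. Compound 3 `O=c1ccc(CCCO)n[nH]1` sits at the same edge, since in this assay compound 3 gives > 100000 nM, again a limit rather than a number. Compound 2 therefore stands at the limit of > 100000 nM in this assay, at which 2 of the 3 values shown sit. The one numerical result comes from compound 1 `CC(C)(C)[Si](OCc1ccc(=O)[nH]n1)(c1ccccc1)c1ccccc1`, which in this assay gives 62600 nM. From the compounds shown here alone, compound 4 `CC(C)(C)[Si](OCCc1ccc(=O)[nH]n1)(c1ccccc1)c1ccccc1` is untested. Against compound 2 the change is a group of 7 heavy atoms (4 carbon, 2 nitrogen, 1 oxygen; one six-membered aromatic ring with 2 hetero atoms) in place of a group of 9 heavy atoms (6 carbon, 2 nitrogen, 1 oxygen; one six-membered aromatic ring with 2 hetero atoms), on a saturated chain carbon, two bonds along the chain from an oxygen on an unsaturated carbon. For the measured compounds named here, no step between measured compounds is available; the direction can be judged only from compound 1, which carries the entering ring and returns a number in this assay at 62600 nM. A step toward stronger inhibition of modest size is expected from compound 2 to compound 4, an at least 1.4-fold lower number from compound 2 to compound 4 (0.15 log units; that floor lies within the scatter). For compound 4 the expected value in this assay is 70000 nM, between 25000 nM and 200000 nM, with a fair chance that only a limit is reported.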

Compound 4, half-maximal inhibitory concentration: 56200 nM
Estimate against measurement, compound 4: 1.2-fold (0.10 log units) above; measured number inside the range.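

In this assay, the change at this position gives a real number where the group that leaves gave none, with an at least 1.7-fold lower number from compound 2 to compound 4 (0.25 log units; that floor lies within the scatter), though that floor alone stays within the scatter. Compound 2 remains a limit and not a number: the limit of > 100000 nM in this assay, at which 2 of the 4 values shown sit. The change on the saturated chain carbon bound to an oxygen, with a 1.1-fold lower number from compound 1 to compound 4 (0.05 log units; within the scatter), lies within the scatter, so compound 1 and compound 4 read as equal and this chain change shows no effect on the read-out.

From the compounds shown here alone, whether a longer chain on the core of compound 4 would keep a measurable number stays open. Also open, going by these compounds, is whether an amine or a carboxylic acid at the chain end, in place of the silyl ether, would do the same.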